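The source may report more compounds than this note shows. Statements on the series, on what has been measured and on what is new or still open speak of the compounds shown alone.

Compound 1 `Cc1c(OCCCCOc2ccc(C(=O)O)c(Cl)c2)ccc(C(=O)CC(C)C)c1C`: 12%
Compound 2 `Cc1c(OCCCCOc2ccc(F)c(C(=O)O)c2)ccc(C(=O)CC(C)C)c1C`: 13.8%
Compound 3 `Cc1c(OCCCCOc2ccc(F)c(C(=O)O)c2)ccc(C(=O)CC2CCCC2)c1C`: 12.6%

In an assay on HEK293 cells for positive allosteric modulation of metabotropic glutamate receptor 3 (Rattus norvegicus), read by thallium flux, with a stated time of 2.5 min (a lower number here means a smaller maximal response, a higher number a larger maximal response), compound 3 gives 12.6%; all three numbers lie within the usual scatter of one another, so compound 3 stands level with compounds 1 and 2. The steps were a number 1.8 percentage points higher from compound 1 to compound 2 (within the scatter) and a number 1.2 percentage points lower from compound 2 to compound 3 (within the scatter).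

Compound 4 `Cc1c(OCCCCOc2ccc(C(=O)O)c(Cl)c2)ccc(C(=O)CC2CCCC2)c1C` differs from compound 3 in one place: 4-carboxy-3-chlorophenyl in place of 3-carboxy-4-fluorophenyl on an oxygen on a saturated carbon. The step from compound 1 to compound 2 is the reverse of this same exchange, and it stayed within the scatter. On that basis no step beyond the scatter is expected in this assay, in either direction. The expected step is a number 1.1 percentage points lower from compound 3 to compound 4 (within the scatter). Compound 4 is therefore estimated at 11.5%, within a range from 7% to 17%.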

Compound 4, largest response reached (reported as percent of maximum), in percent of the reference or control that the assay uses: 35.5%
The estimate for compound 4 lay 24 percentage points below the measured number; the whole stated range lies below it.
By their numbers in this assay, from the lowest: compounds 1, 3 and 2 (each within the scatter of the next); then compound 4.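

In this assay, the two changes act together rather than separately: with cyclopentyl in place, the aryl exchange gives a number 22.9 percentage points higher from compound 3 to compound 4 (beyond the scatter), and with 4-carboxy-3-chlorophenyl in place, the cyclopentyl change gives a number 23.5 percentage points higher from compound 1 to compound 4 (beyond the scatter). The effect of the aryl exchange depends on the core that carries it: the same change on two cores in this assay, a number 1.8 percentage points higher (within the scatter) from compound 1 to compound 2 and a number 22.9 percentage points lower (beyond the scatter) from compound 4 to compound 3, 24.7 percentage points apart, beyond the scatter of two such steps.
The same holds for cyclopentyl in place of isopropyl: the same change on two cores in this assay, a number 1.2 percentage points lower (within the scatter) from compound 2 to compound 3 and a number 23.5 percentage points higher (beyond the scatter) from compound 1 to compound 4, 24.7 percentage points apart, beyond the scatter of two such steps.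

The aryl exchange alters the halogen and the placement of the carboxy group at once, and these four compounds do not separate the two. From the compounds shown here alone, whether cyclohexyl on the saturated chain carbon, or an amide in place of the carboxylic acid, would keep this higher response remains open.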